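Benzyl ether replacement in the series: compound 4

A few compounds are considered here, and "the series" means these few. Any claim that something is new, unique, unknown or untested is made for them only; others in the source may bear on it.

Measured so far in a functional assay on A549 cells (Homo sapiens) for cytotoxicity, read by MTT assay, with a stated time of 72 h; a lower number here means a stronger inhibitor, a higher number a weaker inhibitor:
compound 1 `CCN(CC)CCCCOc1c(OCc2ccccc2)cc(O)c2c(=O)cc(-c3ccccc3)oc12`, 3910 nM
compound 2 `CN1CCN(CCCCOc2c(OCc3ccccc3)cc(O)c3c(=O)cc(-c4ccccc4)oc23)CC1`, 2910 nM
compound 3 `CN1CCN(CCCCOc2c(OCc3ccc(C#N)cc3)cc(O)c3c(=O)cc(-c4ccccc4)oc23)CC1`, 2140 nM

Compound 3 holds the lowest of the three numbers in this assay, but its gap to compound 2 and its gap to compound 1 both sit within the scatter, so the three compounds are not separated on these data. The two measured steps, a 1.3-fold lower number from compound 1 to compound 2 (0.13 log units; within the scatter) and a 1.4-fold lower number from compound 2 to compound 3 (0.13 log units; within the scatter), are each within the scatter as well.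

Compound 4 `CN1CCN(CCCCOc2c(OCc3nc4ccccc4o3)cc(O)c3c(=O)cc(-c4ccccc4)oc23)CC1` is not yet measured. It differs from compound 3 in one place: 1,3-benzoxazol-2-yl in place of 4-cyanophenyl on a saturated chain carbon bound to an oxygen on an aromatic ring. Among the compounds with values here, of the measured steps, only the one from compound 2 to compound 3 touches the same part of the molecule, the aryl group of the benzyl ether, and that step was within the scatter; the step from compound 1 to compound 2 concerns the amine and does not bear on this change. Within the data shown here, no measured step covers the exchange of a carbon-only six-membered aromatic ring for a fused bicyclic group at this position.

With the two measured steps both within the scatter, no step beyond the scatter is expected for compound 4 in this assay, so a 1.1-fold higher number from compound 3 to compound 4 (0.03 log units; within the scatter) is the expected step. Compound 4 is therefore estimated at 2300 nM, within a range from 900 nM to 6000 nM.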

Compound 4, half-maximal inhibitory concentration: 3870 nM
Beside the measured number, compound 4's estimate is 1.7-fold (0.23 log units) below it, and the stated range covers the measured number.
By their numbers in this assay, from the lowest: compounds 3, 2, 4 and 1 (each within the scatter of the next).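

In this assay, a fused bicyclic group on a saturated chain carbon bound to an oxygen on an aromatic ring gives no step beyond the scatter, with a 1.8-fold higher number from compound 3 to compound 4 (0.26 log units; within the scatter) and a 1.3-fold higher number from compound 2 to compound 4 (0.12 log units; within the scatter) both read at this place. The earlier compounds shown here had tested only the addition of a nitrile to the phenyl group, whereas this pair shows that phenyl, 4-cyanophenyl and 1,3-benzoxazol-2-yl remain unseparated here, even with a five-membered aromatic ring entering and the triple bond leaving. No measurement at hand bears on the reason for these numbers.

As far as these compounds go, it remains open whether any group at this place can move the number beyond the scatter, for instance a methyl group, a pyridin-2-yl ring or a phenyl ring carrying a carboxylic acid. From the compounds shown here alone, it is also open whether 1,3-benzoxazol-2-yl reads the same with diethylamino in place of 4-methylpiperazin-1-yl, or with a shorter or longer chain leading to the amine.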